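A few compounds are considered here, and "the series" means these few. Any claim that something is new, unique, unknown or untested is made for them only; others in the source may bear on it.

Measured so far in an assay on isolated protein for inhibition of Flap endonuclease 1 (Homo sapiens); on this read-out lower numbers stand for stronger inhibition and higher numbers for weaker inhibition: compound 1 `O=C(O)C(=O)CC(=O)c1cccc(Cl)c1` gives 6960 nM; compound 2 `O=C(O)C(=O)CC(=O)c1cccc(-c2ccccc2)c1` gives 3620 nM.

Compound 2 holds the smaller of the two numbers, but the step of a 1.9-fold lower number from compound 1 to compound 2 (0.28 log units; within the scatter) stays within the scatter, so compound 2 and compound 1 cannot be told apart on this read-out. Compound 3 `O=C(O)C(=O)CC(=O)c1cccc(Oc2ccccc2)c1` has not been measured; it differs from compound 2 by phenoxy in place of phenyl on an aromatic carbon. Going by the values given here, the only step that bears on this change is the exchange of chloro for phenyl at the same carbon, which stayed within the scatter, so no step beyond the scatter is expected in this assay. For compound 3 the expected value is 3500 nM (range 1500 nM to 8500 nM), an expected step of a 1.0-fold lower number from compound 2 to compound 3 (0.01 log units; within the scatter).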

Compound 3, half-maximal inhibitory concentration: 7310 nM
Compound 3: the middle estimate sits 2.1-fold (0.32 log units) below what was measured, within the range that was stated.
By their numbers in this assay, from the lowest: compounds 2, 1 and 3 (each within the scatter of the next, the first and the last beyond it).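

In this assay, going by these compounds alone, phenoxy in place of phenyl gives a 2.0-fold higher number from compound 2 to compound 3 (0.31 log units; beyond the scatter) at this aromatic carbon, the first step here beyond the scatter, though a modest one. Phenoxy in place of chloro gives a 1.1-fold higher number from compound 1 to compound 3 (0.02 log units; within the scatter) and so leaves compound 3 and compound 1 indistinguishable. No available data explain the phenoxy result.

As far as these compounds go, it remains open whether an amine or a carboxylic acid on the outer ring would shift the number. Benzyloxy, a longer chain in place of phenoxy, also remains untested in these notes.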